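A Third Aryl Group on the Amide Nitrogen

A few compounds are considered here, and "the series" means these few. Any claim that something is new, unique, unknown or untested is made for them only; others in the source may bear on it.

In a functional assay on KB cells (Homo sapiens) for antiproliferative activity, read by sulforhodamine B assay, with a stated time of 3 days (a lower number here means a stronger inhibitor of growth, a higher number a weaker inhibitor of growth), compound 1 (`O=C(Nc1ccccn1)c1cccc(Nc2ncc(F)c(Nc3ccc(F)cc3)n2)c1`) gives 20000 nM and compound 2 (`O=C(Nc1cc(Cl)cc(Cl)c1)c1cccc(Nc2ncc(F)c(Nc3ccc(F)cc3)n2)c1`) gives 20100 nM in the same read-out, so compound 2 stands level with compound 1 within the scatter. Going by the values given here, the only measured step, 3,5-dichlorophenyl in place of pyridin-2-yl on an amide-type nitrogen, is a 1.0-fold higher number from compound 1 to compound 2 (0.00 log units; within the scatter) and shows no change beyond the scatter. Compound 3 (`COc1cc(NC(=O)c2cccc(Nc3ncc(F)c(Nc4ccc(F)cc4)n3)c2)cc(OC)c1`) differs at that same nitrogen: 3,5-dimethoxyphenyl in place of 3,5-dichlorophenyl on an amide-type nitrogen sets out the exchange, 3,5-dimethoxyphenyl in place of 3,5-dichlorophenyl. Among the compounds with values here, no measured compound carries this group, so the flat step of compound 2 from compound 1 is the sole guide, and no step beyond the scatter is expected in this assay for this exchange. The estimated step is a 1.0-fold lower number from compound 2 to compound 3 (0.00 log units; within the scatter) on these two values alone. Compound 3 is estimated at 20000 nM with an expected range from 9000 nM to 40000 nM in this measurement.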

Compound 3, concentration for 50% growth inhibition: 15500 nM
Compound 3: middle estimate off by 1.3-fold (0.11 log units), on the high side; the measured number falls inside the stated range.
By their numbers in this assay, from the lowest: compounds 3, 1 and 2 (each within the scatter of the next).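

In this assay the exchange of 3,5-dichlorophenyl for 3,5-dimethoxyphenyl on the amide-type nitrogen gives a 1.3-fold lower number from compound 2 to compound 3 (0.11 log units; within the scatter) and stays within the scatter, as does the exchange of pyridin-2-yl for the same group, which gives a 1.3-fold lower number from compound 1 to compound 3 (0.11 log units; within the scatter) in this read-out. Going by these compounds alone, the earlier pair showed only that a chlorine-bearing ring and pyridin-2-yl stand level; this result adds that a ring bringing hydrogen-bond acceptors, which the 3,5-dichlorophenyl group lacks, also stands level with both, so three aryl groups at this nitrogen show no step beyond the scatter. No evidence is available to explain why the number stays level across them.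

The compounds shown leave open whether a non-aromatic group on the amide-type nitrogen, such as a butyl chain or a piperidine ring, would move the number beyond the scatter. They also leave open whether any change to the shared core would do so.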